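Methylsulfanyl in place of propargylsulfanyl on the chloro-chain analogue

The source may report more compounds than this note shows. Statements on the series, on what has been measured and on what is new or still open speak of the compounds shown alone.

In a functional assay on B16 cells (Mus musculus) for antiproliferative activity, with a stated time of 72 h (a higher number here means a weaker inhibitor, a lower number a stronger inhibitor), compound 2 `C#CCSc1cnc2ccccc2c1[Se]CC#CCCl` gives 7.1 ug/mL, the highest number of the three measured compounds; compound 1 `CSc1cnc2ccccc2c1[Se]CC#CCOC(=O)c1ccc(C(=O)O)cc1` gives 3.1 ug/mL and compound 3 `CSc1cnc2ccccc2c1[Se]CC#CCOC(=O)/C=C/c1ccccc1` gives 3.1 ug/mL, so compound 2 is the weakest inhibitor of the set. Compound 4 `CSc1cnc2ccccc2c1[Se]CC#CCCl` differs from compound 2 in one place: hydrogen in place of ethynyl on a saturated chain carbon bound to a sulfur.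

Going by the values given here, the only single-point step available, no change at the digits printed from compound 1 to compound 3 (within the scatter), concerns the carbonyl substituent at the far end of the selenium-bound chain and leaves the sulfur substituent untouched; it therefore says nothing about the propargyl-to-methyl exchange. Compounds 1 and 3 both carry methylsulfanyl, as compound 4 does, but they also carry a different chain terminus, so their lower numbers cannot be separated into a sulfur contribution and a chain contribution. Among the compounds with values here, no measured step bears on the change from compound 2 to compound 4.

With nothing to anchor a direction, the expected step of a 1.3-fold lower number from compound 2 to compound 4 (0.11 log units; within the scatter) is taken to lie within the scatter, with a slight lean toward a lower number. Compound 4 is estimated at 5.5 ug/mL in this assay, within a range of 2.5 ug/mL to 12 ug/mL.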

Compound 4, concentration for 50% inhibition: 3.5 ug/mL
Compound 4: the middle estimate sits 1.6-fold (0.20 log units) above what was measured; the measured number falls inside the stated range.
By their numbers in this assay, from the lowest: compounds 1, 3 and 4 (each within the scatter of the next); then compound 2.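

In this assay, going by these compounds alone, exchanging propargyl for methyl on the sulfur while keeping the chloro-terminated chain gives a 2.0-fold lower number from compound 2 to compound 4 (0.31 log units; beyond the scatter), the first reading at this position with the rest of the structure held constant. The step is modest and rests on this one pair, but it shows that the sulfur substituent alone can move the number beyond the scatter, and that the chloro-terminated chain does not by itself set the high number of compound 2: compound 4, with the same chain, gives 3.5 ug/mL, within the scatter of compound 3 at 3.1 ug/mL. Nothing available explains the step, and no supporting measurement bears on it.

As far as these compounds go, it remains open whether a saturated propyl on the sulfur would read like methyl or like propargyl, which would separate the effect of chain length from that of the triple bond, and whether a larger group such as benzyl would continue the trend. From the compounds shown here alone, it also remains open whether the same exchange holds when the selenium-bound chain ends in an ester, as in compound 1 and compound 3, rather than in chlorine.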